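Amide chain extension from compound 3 to compound 4

The source may report more compounds than this note shows. Statements on the series, on what has been measured and on what is new or still open speak of the compounds shown alone.

Three measured compounds share a core. Compound 1, `CC[C@@H]1C(=O)N(C)c2cnc(-n3ccc4cc(F)ccc43)nc2N1C1CCCC1`, gives 16000 nM in a functional assay on Huh-7 cells (Homo sapiens) for antiproliferative activity, read by CCK-8 assay, with a stated time of 72 h; a higher number here means a weaker inhibitor of growth, a lower number a stronger inhibitor of growth. Compound 2, `CC[C@@H]1C(=O)N(C)c2cnc(Nc3ccc(S(=O)(=O)NCCO)cc3)nc2N1C1CCCC1`, gives 278 nM in this assay. Compound 3, `CCC1C(=O)N(C)c2cnc(-n3ccc4cc(C(=O)NC)ccc43)nc2N1c1ccn(C)n1`, gives 13200 nM in this assay. Of the three numbers, compound 3 stands second highest; its number and that of compound 1 lie within the scatter of each other, while the number of compound 2 is far lower, beyond the scatter. No two of the measured compounds differ in a single place, so no single-step change has yet been measured in this set.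

Compound 4, `CCCCNC(=O)c1ccc2c(ccn2-c2ncc3c(n2)N(c2ccn(C)n2)C(CC)C(=O)N3C)c1`, is not yet measured. It differs from compound 3 in one place: propyl in place of hydrogen on a saturated chain carbon bound to an amide-type nitrogen. Cut one bond further out, the same change reads methylcarbamoyl to butylcarbamoyl. For the measured compounds named here, nothing among the measured compounds speaks to this change, and no comparable step is available. The expected step of a 1.3-fold lower number from compound 3 to compound 4 (0.12 log units; within the scatter) is small, with no direction beyond the scatter expected. Compound 4 is estimated at 10000 nM in this assay, with an expected range from 4000 nM to 30000 nM.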

Compound 4, concentration for 50% growth inhibition: 8670 nM
Compound 4: the middle estimate sits 1.2-fold (0.06 log units) above what was measured, within the range that was stated.
By their numbers in this assay, from the lowest: compound 2; then compounds 4, 3 and 1 (each within the scatter of the next).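

In this assay, the change from methylcarbamoyl to butylcarbamoyl gives a 1.5-fold lower number from compound 3 to compound 4 (0.18 log units; within the scatter), the first single-place comparison available in this series. This step shows that propyl in place of hydrogen on a saturated chain carbon bound to an amide-type nitrogen leaves the growth-inhibition number unresolved from that of the methyl amide, so this single extension to butyl yields no measurable gain or loss. No measurement shown bears on the reason for this outcome.

From the compounds shown here alone, whether a longer chain, a terminal amine or a carboxylic acid at the end of the same amide chain would produce a step beyond the scatter remains open. A single step also leaves open whether hydroxyl at the end of the butyl chain would read differently from the plain butyl group.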